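Swapping Methyl for Fluoro on an Aromatic Ring

The source may hold more compounds than are shown below. What is called first, only, known or untested is meant among the compounds shown, and "the series" means these compounds.

Compound 1: `COc1ccc(/C=C2\SC(=O)N(Cc3ccc(C(=O)O)cc3)C2=O)cc1`; 48000 nM
Compound 2: `O=C(O)c1ccc(CN2C(=O)S/C(=C\c3ccccc3)C2=O)cc1`; 100000 nM
Compound 3: `Cc1ccc(/C=C2\SC(=O)N(Cc3ccc(C(=O)O)cc3)C2=O)cc1`; 100000 nM

All three share one core and were tested in a functional assay on MCF7 cells (Homo sapiens) for cytotoxicity, read by MTT assay, with a stated time of 24 h; a lower number here means a stronger inhibitor, a higher number a weaker inhibitor. Compound 3 stands level with compound 2 at the digits shown, and together they give the highest numbers of the three; the only compound set apart is compound 1, with a 2.1-fold higher number from compound 1 to compound 3 (0.32 log units; beyond the scatter). The methyl of compound 3 against the hydrogen of compound 2 makes no change at the digits printed from compound 2 to compound 3 (within the scatter).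

Compound 4, `O=C(O)c1ccc(CN2C(=O)S/C(=C\c3ccc(F)cc3)C2=O)cc1`, differs from compound 3 in a single place: fluoro in place of methyl on an aromatic carbon. Among the compounds with values here, two measured steps bear on this position. Exchanging hydrogen for methyl gave no change, and exchanging methoxy for either of them gave only a modest shift, a 2.1-fold higher number from compound 1 to compound 2 (0.32 log units; beyond the scatter). A small halogen at the same place is therefore not expected to move this assay beyond its scatter. Compound 4 is expected to give about 100000 nM, between 45000 nM and 200000 nM. The step this estimate implies, no change at the digits printed from compound 3 to compound 4 (within the scatter), is expected to lie within the scatter.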

Compound 4, half-maximal inhibitory concentration: 38000 nM
For compound 4 the middle estimate is 2.6-fold (0.42 log units) above the measured one; measured number outside the range, below it.
By their numbers in this assay, from the lowest: compounds 4 and 1 (each within the scatter of the next); then compounds 2 and 3 (each within the scatter of the next).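

In this assay, within the data shown here, this position proves more sensitive than the earlier compounds suggested: fluoro separates from both methyl and hydrogen, with a 2.6-fold lower number from compound 3 to compound 4 (0.42 log units; beyond the scatter) and a 2.6-fold lower number from compound 2 to compound 4 (0.42 log units; beyond the scatter) on the two comparisons. Fluoro and methoxy, however, cannot be told apart, with a 1.3-fold lower number from compound 1 to compound 4 (0.10 log units; within the scatter), so the four compounds now fall into two pairs, compounds 1 and 4 on one side and compounds 2 and 3 on the other. Nothing measured here gives a reason for this split.

On these data alone, whether a chlorine atom, an amine or a longer chain at this place would fall with the first pair or the second remains open. As far as these compounds go, with every number coming from this assay, it is also open whether the same two pairs would appear in another cell line.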